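A few compounds are considered here, and "the series" means these few. Any claim that something is new, unique, unknown or untested is made for them only; others in the source may bear on it.

In a functional assay for antagonist activity at transient receptor potential cation channel subfamily V member 1 (Rattus norvegicus) (a higher number here means a weaker inhibitor, a lower number a stronger inhibitor), compound 1 `CC(C)(C)c1ccc(CCC(=S)NCc2ccc(NS(C)(=O)=O)c(I)c2)cc1` gives 300 nM. Compound 2 `CC(C)(C)c1ccc(CCC(=S)NCc2ccc(NS(C)(=O)=O)c(C(F)(F)F)c2)cc1` gives 940 nM, the higher of the two numbers seen so far; the difference between them is a 3.1-fold higher number from compound 1 to compound 2 (0.50 log units; beyond the scatter). Compound 3 `CCc1cc(CNC(=S)CCc2ccc(C(C)(C)C)cc2)ccc1NS(C)(=O)=O` differs from compound 2 by one change: ethyl in place of trifluoromethyl on an aromatic carbon. Going by the values given here, the only measured step concerns this same position, and it was modest. Among the compounds with values here, no step compares two groups of the present kind, so compound 3 is expected to land near compound 2, the estimated step being a 1.1-fold higher number from compound 2 to compound 3 (0.03 log units; within the scatter). Compound 3 is therefore estimated at 1000 nM, with a range from 300 nM to 3500 nM.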

Compound 3, half-maximal inhibitory concentration: 240 nM
The estimate for compound 3 lay 4.2-fold (0.62 log units) above the measured number; measured number outside the range, below it.
By their numbers in this assay, from the lowest: compounds 3 and 1 (each within the scatter of the next); then compound 2.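

Ethyl and trifluoromethyl are not interchangeable at this position, ortho to a methanesulfonamido group: replacing one with the other gives a 3.9-fold lower number from compound 2 to compound 3 (0.59 log units; beyond the scatter). Ethyl and iodo, by contrast, cannot be told apart here, with a 1.3-fold lower number from compound 1 to compound 3 (0.10 log units; within the scatter), a gap within the usual scatter. No available measurement gives a reason for the difference between ethyl and trifluoromethyl. From the compounds shown here alone, it remains open whether a longer chain such as propyl, or a methoxy or amine group, would give a number close to those of compound 1 and compound 3 or one close to that of compound 2.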